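The compounds below may be only part of what the source reports. "The series", "measured", "known", "first", "only" and "open" are said of these compounds alone.

The study covers four compounds built on a shared core, three of them measured and one still to be tested. Compound 1 `C=C1C(=O)[C@]23C[C@@]1(O)CC[C@H]2c1ccc(O)c(C)c1[C@@H]3Cn1cc(-c2ccccc2)nn1` carries a phenyl, and in a functional assay on HL-60 cells (Homo sapiens) for cytotoxicity, read by MTT assay, with a stated time of 4 days (on this read-out lower numbers stand for stronger inhibition and higher numbers for weaker inhibition), compound 1 gives 750 nM. Compound 2 `C=C1C(=O)[C@]23C[C@@]1(O)CC[C@H]2c1ccc(O)c(C)c1[C@@H]3Cn1cc(-c2ccc(C(F)(F)F)cc2)nn1` differs from compound 1 by trifluoromethyl in place of hydrogen on an aromatic carbon, and in this assay compound 2 gives 720 nM. The step of a 1.0-fold lower number from compound 1 to compound 2 (0.02 log units; within the scatter) is one that the measurement cannot separate from repeat-to-repeat noise.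

Compound 3 `C=C1C[C@]23C[C@@]1(O)CC[C@H]2c1ccc(OS(=O)(=O)c2ccc(C)cc2)c(C)c1[C@@H]3Cn1cc(-c2ccccc2)nn1` rests on a core that is changed relative to compound 1, and the difference between the two cores is not broken down here. In this assay compound 3 reaches only the limit of the assay, > 20000 nM. This is the limit of > 20000 nM in this assay, at which 1 of the 3 values shown sits.

Compound 4 `C=C1C[C@]23C[C@@]1(O)CC[C@H]2c1ccc(OS(=O)(=O)c2ccc(C)cc2)c(C)c1[C@@H]3Cn1cc(-c2ccc(C(F)(F)F)cc2)nn1` has not yet been measured. It differs from compound 3 by trifluoromethyl in place of hydrogen on an aromatic carbon, the same change as that from compound 1 to compound 2, at a place described in the same words. Because the measured step of a 1.0-fold lower number from compound 1 to compound 2 (0.02 log units; within the scatter) lies within the scatter, the expected step that the limit leaves unreadable from compound 3 to compound 4 is likewise estimated to be small. Since compound 3 stands only at a limit, compound 4 is expected most likely to stay at that limit as well, with an estimate of 25000 nM and a range from 8000 nM to 80000 nM.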

Compound 4, half-maximal inhibitory concentration: > 20000 nM
Compound 4: no number, only a limit (the forecaster's own chance of this, stated with the estimate: 75%); the middle value lies beyond the limit too.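

In this assay, among the compounds shown here, compound 4 gives > 20000 nM, which is a limit of the assay and not a number: the limit of > 20000 nM in this assay, at which 2 of the 4 values shown sit. Compound 3 stands at a limit too, so no step between compound 3 and compound 4 can be read. The compounds shown leave open how far compound 3 and compound 4 lie past that limit, and whether trifluoromethyl in place of hydrogen changes anything on their shared core.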